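Reinstating the Carbamoylamino Linker with a Chlorophenyl

The compounds below may be only part of what the source reports. "The series", "measured", "known", "first", "only" and "open" are said of these compounds alone.

Compound 1 `COc1cc(NC(C)CCCNC(=O)NNC(=O)Nc2ccc(O)cc2)c2ncccc2c1` gives 104000 nM in a functional assay on MOLT-4 cells (Homo sapiens) for inhibition, read by MTT assay, with a stated time of 72 h; a higher number here means a weaker inhibitor, a lower number a stronger inhibitor.
Compound 2 `COc1cc(NC(C)CCCNC(=O)Nc2cccc(Cl)c2)c2ncccc2c1` gives 21000 nM in this assay.

Among the measured compounds shown here, compound 2 stands at the lowest of the two numbers in this assay; its only neighbour is compound 1, reached by the step of a 5.0-fold lower number from compound 1 to compound 2 (0.69 log units; beyond the scatter). Compound 3 `COc1cc(NC(C)CCCNC(=O)NNC(=O)Nc2ccc(Cl)cc2)c2ncccc2c1` differs from compound 2 by ((4-chlorophenyl)carbamoyl)amino in place of 3-chlorophenyl on an amide-type nitrogen. For the measured compounds named here, the single measured step bearing on this, a 5.0-fold lower number from compound 1 to compound 2 (0.69 log units; beyond the scatter), ran the other way and also exchanged a hydroxyphenyl for a chlorophenyl, so it only partly predicts the return. Compound 3 is therefore expected to give a higher number than compound 2, by a 2.9-fold higher number from compound 2 to compound 3 (0.46 log units; beyond the scatter), short of a full reversal. The estimate for compound 3 is 60000 nM, ranging from 20000 nM to 160000 nM.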

Compound 3, half-maximal inhibitory concentration: 186000 nM
Compound 3: middle estimate off by 3.1-fold (0.49 log units), on the low side; the whole stated range lies below it.
By their numbers in this assay, from the lowest: compound 2; then compounds 1 and 3 (each within the scatter of the next).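

In this assay, ((4-chlorophenyl)carbamoyl)amino in place of 3-chlorophenyl on the amide-type nitrogen gives an 8.9-fold higher number from compound 2 to compound 3 (0.95 log units; beyond the scatter) and thus shows that a chlorophenyl alone does not secure the lower number of compound 2. Chloro in place of hydroxy on an aromatic carbon gives a 1.8-fold higher number from compound 1 to compound 3 (0.25 log units; within the scatter) and so does not separate these two compounds. Nothing measured here gives a reason for these results.

From the compounds shown here alone, it remains open whether the larger step belongs to the carbamoylamino linker or to the chlorine's place on the ring. Also open, going by these compounds, is how an amine or a carboxylic acid on that ring would read.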